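Difluorophenyl for trifluoromethylphenyl at the chalcone carbonyl

The source may hold more compounds than are shown below. What is called first, only, known or untested is meant among the compounds shown, and "the series" means these compounds.

Compound 1 `COC(=O)c1cc(-c2cccc(NC(=O)c3ccc(/C=C/C(=O)c4cccc(C(F)(F)F)c4)cc3)c2)on1` is the reference of this small set. In an ADME assay on Vero cells (Chlorocebus sabaeus) for cytotoxicity, read by MTT assay, with a stated time of 72 h (on this read-out higher numbers stand for lower toxicity in this test and lower numbers for higher toxicity in this test), compound 1 reaches only a limit, > 20 ug/mL. Compound 2 `COC(=O)c1cc(-c2cccc(NC(=O)c3ccc(/C=C/C(=O)c4cccc(OC)c4)cc3)c2)on1` likewise gives only a limit, > 100 ug/mL. Compound 3 `COC(=O)c1cc(-c2cccc(NC(=O)c3ccc(/C=C/C(=O)c4ccc(CC(C)C)cc4)cc3)c2)on1` also stops at a limit, > 10 ug/mL. The step from compound 1 to compound 2 is a step that the two limits leave unreadable from compound 1 to compound 2, that from compound 1 to compound 3 is a step that the two limits leave unreadable from compound 1 to compound 3, and that from compound 2 to compound 3 is a step that the two limits leave unreadable from compound 2 to compound 3; none of them can be sized because of the limit of > 10 ug/mL in this assay, at which 1 of the 3 values shown sits, the limit of > 100 ug/mL in this assay, at which 1 of the 3 values shown sits, and (the limit of > 20 ug/mL in this assay, at which 1 of the 3 values shown sits). Compound 4 `COC(=O)c1cc(-c2cccc(NC(=O)c3ccc(/C=C/C(=O)c4ccc(F)cc4F)cc3)c2)on1` differs from compound 1 by 2,4-difluorophenyl in place of 3-(trifluoromethyl)phenyl on a carbonyl carbon. Since every measured aryl change at this carbonyl carbon left the value at a limit, no shift beyond the scatter is expected, and the step is estimated as a step that the limit leaves unreadable from compound 1 to compound 4. Compound 4 is therefore expected to give about 50 ug/mL, within 20 ug/mL to 150 ug/mL.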

Compound 4, half-maximal cytotoxic concentration: > 40 ug/mL
Compound 4 was reported as a limit; the forecaster's own chance of this, stated with the estimate: 80%; the middle value is on the limit's open side.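

In this assay compound 4 also gives only a limit, so the steps from compound 1, compound 2 and compound 3 to compound 4 cannot be read. The compounds shown leave open whether changing the aryl group on this carbonyl carbon alters cytotoxicity at all.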